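The source may report more compounds than this note shows. Statements on the series, on what has been measured and on what is new or still open speak of the compounds shown alone.

Measured so far:
compound 1 `Cc1nc(Nc2ccccc2)c2cc[nH]c2n1` — 550000000 nM
compound 2 `Cc1nc(Nc2ccc(F)cc2)c2cc[nH]c2n1` — 372000000 nM

In a functional assay on the whole organism for inhibition, with Nicotiana tabacum as the target (a higher number here means a weaker inhibitor, a lower number a stronger inhibitor), compound 1 gives 550000000 nM and compound 2 gives 372000000 nM. Of these two numbers, compound 2 holds the lower one, yet the step of a 1.5-fold lower number from compound 1 to compound 2 (0.17 log units; within the scatter) is within the scatter of repeated measurements, so the two compounds cannot be told apart on these data. Compound 3 `Cc1nc(Nc2ccc(Cl)cc2)c2cc[nH]c2n1` is the next member of this series and has not yet been measured. It differs from compound 2 in one place: chloro in place of fluoro on an aromatic carbon. Among the compounds with values here, only one measured step touches on this change, namely the exchange of hydrogen for fluoro on an aromatic carbon, a 1.5-fold lower number from compound 1 to compound 2 (0.17 log units; within the scatter), and that step stayed within the scatter. Within the data shown here, there is no measured step with chloro, so nothing points to a large shift in either direction. The step of a 1.2-fold lower number from compound 2 to compound 3 (0.09 log units; within the scatter) is therefore expected to remain within the scatter. Compound 3 is expected to give about 300000000 nM, with a likely range from 100000000 nM to 900000000 nM.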

Compound 3, half-maximal inhibitory concentration: 224000000 nM
For compound 3 the middle estimate is 1.3-fold (0.13 log units) above the measured one; the range from low to high includes it.
By their numbers in this assay, from the lowest: compounds 3, 2 and 1 (each within the scatter of the next, the first and the last beyond it).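

In this assay, within the data shown here, chloro on the aromatic carbon para to a large group gives the first step that can be told apart from the scatter of repeated measurements, a 2.5-fold lower number from compound 1 to compound 3 (0.39 log units; beyond the scatter), so replacing hydrogen at this position can shift the number, though only modestly. Swapping one halogen for the other at the same place does not separate the compounds, since a 1.7-fold lower number from compound 2 to compound 3 (0.22 log units; within the scatter) leaves compound 2 and compound 3 indistinguishable on these data. Nothing measured alongside these numbers explains why chloro produces a step that clears the scatter.

From the compounds shown here alone, it remains open whether bromo, or a group of a different kind such as methoxy, an amine or a carboxylic acid, would move the number further at this position, and whether any such group would bring a much larger step than the modest one seen with chloro. Also unresolved is whether chloro would give a similar step on another carbon of the same ring, or whether this effect belongs to this one position.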